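Working notes: chloro addition from compound 3 to compound 4

The source may hold more compounds than are shown below. What is called first, only, known or untested is meant among the compounds shown, and "the series" means these compounds.

Measured so far:
compound 1 `Cc1ccc(Nc2nc(C)c(C(=O)/C=C/c3ccccc3)s2)cc1`, > 25000 nM
compound 2 `Cc1nc(Nc2ccc(Cl)c(Cl)c2)sc1C(=O)/C=C/c1ccc(Cl)cc1`, 22700 nM
compound 3 `Cc1nc(Nc2cccc(Cl)c2)sc1C(=O)/C=C/c1ccccc1`, > 25000 nM

In a functional assay on BGC-823 cells (Homo sapiens) for cytotoxicity, read by MTT assay (on this read-out higher numbers stand for weaker inhibition and lower numbers for stronger inhibition), compound 1 gives > 25000 nM, which is a limit of the assay and not a number. Compound 3 likewise gives only > 25000 nM, a limit of the assay. Compound 2 gives 22700 nM. Going by the values given here, the single step between neighbours, a step that the two limits leave unreadable from compound 1 to compound 3, cannot be read because both ends sit at the limit of > 25000 nM in this assay, at which 2 of the 3 values shown sit. Compound 3 thus stands at the limit alongside compound 1, with no readable step to place it. Compound 4 `Cc1nc(Nc2ccc(Cl)c(Cl)c2)sc1C(=O)/C=C/c1ccccc1` is not yet measured; it differs from compound 3 by chloro in place of hydrogen on an aromatic carbon. Among the compounds with values here, no measured step bears on this change, so no direction beyond the scatter is expected. Compound 4 is expected to give 25000 nM, within 12000 nM to 50000 nM, an expected step of a number no higher from compound 3 to compound 4 (the limit leaves the size open).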

Compound 4, half-maximal inhibitory concentration: 10600 nM
For compound 4 the middle estimate is 2.4-fold (0.37 log units) above the measured one, outside the stated range (below it).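

In this assay, going by these compounds alone, chloro in place of hydrogen on the aromatic carbon para to a large group gives an at least 2.3-fold lower number from compound 3 to compound 4 (0.37 log units; beyond the scatter), the first readable step for a change on this ring, and 3,4-dichlorophenyl in place of 4-methylphenyl gives an at least 2.3-fold lower number from compound 1 to compound 4 (0.37 log units; beyond the scatter). Hydrogen in place of chloro on an aromatic carbon gives a 2.1-fold lower number from compound 2 to compound 4 (0.33 log units; beyond the scatter), so the lower number in this pair goes with the compound lacking that chloro. The step between the two limits cannot be read: the limit of > 25000 nM in this assay, at which 2 of the 4 values shown sit.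

On these data alone, whether a methoxy group or an amine on the same carbon would keep the lower number remains open.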